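The compounds below may be only part of what the source reports. "The series", "measured", "known", "first", "only" and "open" are said of these compounds alone.

In a functional assay on A-431 cells (Homo sapiens) for antiproliferative activity, read by MTT assay, with a stated time of 72 h (a lower number here means a stronger inhibitor, a higher number a weaker inhibitor), compound 1 `COc1ccc(Nc2ncnc3ccc(NC(=O)Nc4ccc(CN5CCN(C)CC5)cc4)cc23)cc1Cl` gives 2010 nM and compound 2 `CN(C)Cc1ccc(NC(=O)Nc2ccc3ncnc(Nc4cccc(C(F)(F)F)c4)c3c2)cc1` gives 1030 nM. Within the data shown here, these two numbers lie within the usual scatter of each other, so compound 2 stands level with the only other measured compound. Compound 3 `CCN(CC)c1ccc(NC(=O)Nc2ccc3ncnc(Nc4cccc(C(F)(F)F)c4)c3c2)cc1` carries diethylamino in place of (dimethylamino)methyl on an aromatic carbon, para to a large group (diethylamino in place of (dimethylamino)methyl on an aromatic carbon). Among the measured compounds shown here, no measured pair shows this change, so the expectation is for no step beyond the scatter in this assay. The expected change is a 1.2-fold higher number from compound 2 to compound 3 (0.07 log units; within the scatter), with no firm direction. For compound 3 the estimate is 1200 nM, within a range of 350 nM to 4500 nM.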

Compound 3, half-maximal inhibitory concentration: 6460 nM
Beside the measured number, compound 3's estimate is 5.4-fold (0.73 log units) below it; measured number outside the range, above it.
By their numbers in this assay, from the lowest: compounds 2 and 1 (each within the scatter of the next); then compound 3.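

In this assay this aromatic carbon is not indifferent to what it carries, since diethylamino in place of (dimethylamino)methyl gives a 6.3-fold higher number from compound 2 to compound 3 (0.80 log units; beyond the scatter). Neither group has a ring or a net charge, so even a swap between two open-chain amine groups can weaken the compound here. No measured evidence accounts for this step.

The change alters both the groups on the nitrogen and the carbon link to the ring, and this one step cannot separate the two. Dimethylamino or (diethylamino)methyl at this position would tell them apart.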